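The source may report more compounds than this note shows. Statements on the series, on what has been measured and on what is new or still open speak of the compounds shown alone.

Compound 1 `CCN1CCN(c2cc(C)c3cc(NC(=O)c4ccc(C)cc4)ccc3n2)CC1`: 6740 nM
Compound 2 `CCN(CC)CCNc1cc(C)c2cc(NC(=O)c3ccc(Cl)c(Cl)c3)ccc2n1`: 1420 nM

In a functional assay on MCF7 cells (Homo sapiens) for antiproliferative activity, read by MTT assay, with a stated time of 72 h (a lower number here means a stronger inhibitor, a higher number a weaker inhibitor), compound 1 stands at the higher of the two numbers; compound 2 gives the lower one, and that gap lies beyond the usual scatter. Compound 3 `CCN1CCN(c2cc(C)c3cc(NC(=O)c4ccc5ccccc5n4)ccc3n2)CC1` has not been measured in this assay. It differs from compound 1 in one place: quinolin-2-yl in place of 4-methylphenyl on a carbonyl carbon. Within the data shown here, no step between two measured compounds tracks this change, so its size rests on no directly comparable pair. Compound 3 is expected to show a modest step toward a lower number, a 3.1-fold lower number from compound 1 to compound 3 (0.49 log units; beyond the scatter), beyond the scatter but not large. Compound 3 is estimated at 2200 nM, within 600 nM to 8000 nM.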

Compound 3, half-maximal inhibitory concentration: 7060 nM
Compound 3: middle estimate off by 3.2-fold (0.51 log units), on the low side; the measured number falls inside the stated range.
By their numbers in this assay, from the lowest: compound 2; then compounds 1 and 3 (each within the scatter of the next).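

In this assay, quinolin-2-yl in place of 4-methylphenyl on the carbonyl carbon gives a 1.0-fold higher number from compound 1 to compound 3 (0.02 log units; within the scatter), so this assay does not tell the two groups apart at this position. That holds even though quinolin-2-yl brings a second aromatic ring and a hydrogen-bond acceptor. Nothing available explains why the two groups read alike.

Still open, on these data alone, is whether a pyridin-2-yl group, or a phenyl ring carrying an amine or a carboxylic acid, on this carbonyl carbon would separate from compound 1. Also open, as far as these compounds go, is whether quinolin-2-yl would read the same on the diethylaminoethylamino side chain of compound 2.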